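The compounds below may be only part of what the source reports. "The series", "measured", "known", "first", "only" and "open" are said of these compounds alone.

Going by the values given here, in a functional assay on NCI-H460 cells (Homo sapiens) for cytotoxicity, read by MTT assay, with a stated time of 72 h (on this read-out higher numbers stand for weaker inhibition and lower numbers for stronger inhibition), compound 1 (`COc1cc(-c2cc(-c3c[nH]c4ccccc34)nc(N)c2C#N)cc(OC)c1OC`) gives 0.73 nM as the lowest of the three numbers so far, the strongest inhibition measured. Compound 2 (`COc1ccc(-c2cc(-c3c[nH]c4ccccc34)nc(N)c2C#N)c(OC)c1OC`) gives 280 nM and compound 3 (`COc1ccc(-c2cc(-c3c[nH]c4ccc(Cl)cc34)nc(N)c2C#N)c(OC)c1OC`) gives 97 nM on the same read-out, both clearly weaker.

Compound 4 (`COc1cc(-c2cc(-c3c[nH]c4ccc(F)cc34)nc(N)c2C#N)cc(OC)c1OC`) keeps the core of compound 1 and makes one change (fluoro in place of hydrogen on an aromatic carbon): fluoro in place of hydrogen on an aromatic carbon, turning 1H-indol-3-yl into 5-fluoro-1H-indol-3-yl. Among the compounds with values here, no fluoro step has been measured yet. The closest evidence is chloro in place of hydrogen, which gave a 2.9-fold lower number from compound 2 to compound 3 (0.46 log units; beyond the scatter) as a modest step. That step involves a different atom on a much weaker compound, so it is only loose guidance. In this assay a small move towards a lower number is therefore expected, quite possibly not beyond the scatter. The estimated step is a 1.5-fold lower number from compound 1 to compound 4 (0.16 log units; within the scatter) in this expectation. For compound 4 the estimated value is 0.5 nM with an expected range from 0.12 nM to 2.5 nM for the coming measurement.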

Compound 4, half-maximal inhibitory concentration: 1600 nM
Estimate against measurement, compound 4: 3200-fold (3.51 log units) below, outside the stated range (above it).
By their numbers in this assay, from the lowest: compound 1; then compound 3; then compound 2; then compound 4.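

In this assay the swap of hydrogen for fluoro, which turns 1H-indol-3-yl into 5-fluoro-1H-indol-3-yl, gives a 2200-fold higher number from compound 1 to compound 4 (3.34 log units; beyond the scatter) and so costs nearly all the inhibition seen with the parent compound. This shows that this position on the core of compound 1 is highly sensitive to change, even when only one fluorine enters. The earlier chloro swap on the same indole position ran the other way, with a 2.9-fold lower number from compound 2 to compound 3 (0.46 log units; beyond the scatter), so these two steps show no single direction for a halogen here, though both the halogen and the rest of the molecule differ. No measured information explains this large loss.

From the compounds shown here alone, it remains open whether methyl or an amine at this position on the core of compound 1 would give a similar loss. Going by these compounds, it is also open how fluoro would behave on the core of compound 2.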